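The compounds below may be only part of what the source reports. "The series", "measured", "known", "first", "only" and "open" are said of these compounds alone.

Measured compounds:
Compound 1, `COc1ccc2[nH]c(C(=O)N3CC(=O)N(Cc4ccccc4)[C@@H](COc4ccccc4)C3)cc2c1`, gives 12200 nM in a physicochemical assay for solubility, read by spectrophotometry, in phosphate buffer, with a stated time of 2 h, at pH 7.4; a lower number here means a less soluble compound, a higher number a more soluble compound.
Compound 2, `COc1ccc2[nH]c(C(=O)N3CC(=O)N(Cc4ccccc4)[C@@H](CN4CCC(OC)CC4)C3)cc2c1`, gives > 25000 nM in this assay, which is a limit of the assay and not a number.

Among the compounds with values here, compound 1 is the only compound here with a real number in this assay; the one other value shown is a limit, (the limit of > 25000 nM in this assay, at which 1 of the 2 values shown sits). Compound 3, `COc1ccc2[nH]c(C(=O)N3CC(=O)N(Cc4ccccc4)[C@@H](CCN4CCC5(CC4)CC5)C3)cc2c1`, has not yet been measured. It differs from compound 1 at one place: a group of 9 heavy atoms (8 carbon, 1 nitrogen; one three-membered non-aromatic ring of carbon only, one six-membered non-aromatic ring with 1 hetero atom) in place of a group of 7 heavy atoms (6 carbon, 1 oxygen; one six-membered aromatic ring of carbon only), on a saturated chain carbon bound to a saturated ring carbon.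

Within the data shown here, one measured step bears on this change. The replacement of the phenoxy group by 4-methoxypiperidin-1-yl at the same position produced an at least 2.0-fold higher number from compound 1 to compound 2 (0.31 log units; beyond the scatter). Compound 3 likewise loses the phenoxy group and gains a group whose six-membered non-aromatic ring carries one hetero atom, a nitrogen, so the same direction of change is expected, with the size uncertain because the step to compound 2 ends at a limit.

Compound 3 is therefore expected to give 25000 nM in this assay, in the range 10000 nM to 60000 nM, which is a step of a 2.0-fold higher number from compound 1 to compound 3 (0.31 log units; beyond the scatter).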

Compound 3, solubility: > 25000 nM
Compound 3: no number, only a limit (the forecaster's own chance of this, stated with the estimate: 55%); the middle value lies on the limit itself.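

In this assay, a second replacement of the phenoxy group on a saturated chain carbon bound to a saturated ring carbon gives an at least 2.0-fold higher number from compound 1 to compound 3 (0.31 log units; beyond the scatter), and this time the entering group holds only carbon and nitrogen, with a six-membered non-aromatic ring and a three-membered ring of carbon only, so the oxygen of the 4-methoxypiperidin-1-yl group in compound 2 is not needed for a step of this kind among the compounds shown. Compound 3 gives > 25000 nM, which is a limit of the assay and not a number. The step from compound 2 to compound 3 cannot be read, and the two values sit together at one limit: the limit of > 25000 nM in this assay, at which 2 of the 3 values shown sit.

The compounds shown leave open how far the two nitrogen-bearing groups differ from each other in this assay, as neither has a number there. They also leave open whether the ring nitrogen matters at this place, which a cyclohexyl group of carbon only, an open-chain dimethylamino group or a carboxylic acid on the same chain carbon would begin to address.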